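This account rests on a few compounds, and the source may have more. Where it says the series, first, only, none or still open, it means among the compounds named here.

Of the compounds shown here, three sharing one core have numbers so far in a functional assay on KB cells (Homo sapiens) for cytotoxicity; on this read-out higher numbers stand for weaker inhibition and lower numbers for stronger inhibition: compound 1 `C=CCOc1ccc2c(c1)C(=O)C=CC2=O` gives 10200 nM, compound 2 `O=C1C=CC(=O)c2cc(OCc3ccccc3)ccc21` gives 26200 nM and compound 3 `CCOc1ccc2c(c1)C(=O)C=CC2=O` gives 21400 nM. Compound 3 sits with compound 2 in the upper pair of numbers, the step between them being a 1.2-fold lower number from compound 2 to compound 3 (0.09 log units; within the scatter). Its gap to the lowest number is a 2.1-fold higher number from compound 1 to compound 3 (0.32 log units; beyond the scatter).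

Compound 4 `CC(=O)Oc1ccc2c(c1)C(=O)C=CC2=O` carries acetoxy where compound 3 has ethoxy, that is, acetyl in place of ethyl on an oxygen on an aromatic ring.

Within the data shown here, no measured step makes this change. All three exchange a group on a saturated chain carbon bound to that oxygen, and none puts acetyl on the oxygen itself. They serve only as a gauge of how far the numbers have moved with changes in this part of the series: the largest is a 2.6-fold higher number from compound 1 to compound 2 (0.41 log units; beyond the scatter), which is modest, and a 1.2-fold lower number from compound 2 to compound 3 (0.09 log units; within the scatter) is the smallest. On that gauge, a modest step at most is expected in this assay, with the direction left open by the data and a slight lean towards a lower number. The estimate amounts to a 1.3-fold lower number from compound 3 to compound 4 (0.13 log units; within the scatter), an expected step that stays small. For compound 4 the estimated value is 16000 nM, with an expected range of 6000 nM to 40000 nM.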

Compound 4, half-maximal inhibitory concentration: 22100 nM
Estimate against measurement, compound 4: 1.4-fold (0.14 log units) below, within the range that was stated.
By their numbers in this assay, from the lowest: compound 1; then compounds 3, 4 and 2 (each within the scatter of the next).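

Acetyl on the oxygen on an aromatic ring is the first group in the series to bring a carbonyl to this place, and in this assay the exchange for ethyl gives a 1.0-fold higher number from compound 3 to compound 4 (0.01 log units; within the scatter), so the extra hydrogen-bond acceptor and the extra heavy atom bring no separable difference between these two compounds. Among these compounds, the comparison with allyl gives a 2.2-fold higher number from compound 1 to compound 4 (0.34 log units; beyond the scatter) and remains modest, which leaves compound 1 as the only compound with printed steps beyond the scatter to all three others, while ethoxy, benzyloxy and acetoxy cannot be separated by their steps. No supporting data bear on why allyl alone stands apart from the other groups on this oxygen.

On these data alone, whether a longer chain, a free hydroxyl or a chain ending in an amine or a carboxylic acid on this oxygen would give a step larger than the modest ones seen so far stays open. As far as these compounds go, all four compounds vary only at this one place, so the contribution of the rest of the shared core to these numbers also remains open.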